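Vasopressin V2 agonists: an aryl urea exchanged for a carboxymethyl

A few compounds are considered here, and "the series" means these few. Any claim that something is new, unique, unknown or untested is made for them only; others in the source may bear on it.

The three measured compounds share one core and differ at a single aromatic ring. In a functional assay on HEK293 cells for agonist activity at Vasopressin V2 receptor (Homo sapiens), read by a luciferase reporter and cAMP accumulation (on this read-out higher numbers stand for an effect only at larger amounts of compound and lower numbers for an effect already at smaller amounts), compound 1 `O=C(NCc1ccc(C(=O)N2CCCCc3ccccc32)c(F)c1)Nc1c(F)cccc1F` gives 180 nM. Among the compounds with values here, compound 2 `O=C(NCc1ccc(C(=O)N2CCCCc3ccccc32)c(Cl)c1)Nc1c(F)cccc1F` gives 40 nM in this assay, and the step of a 4.5-fold lower number from compound 1 to compound 2 (0.65 log units; beyond the scatter) is the only step between measured compounds that differ in one place. Compound 3 `Cc1cc(C(=O)N2CCCCc3ccccc32)ccc1CNC(=O)Nc1c(F)cccc1F` stands lowest of the three in this assay with 2.1 nM, beyond the scatter from both compound 2 and compound 1.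

Compound 4 `Cc1cc(C(=O)N2CCCCc3ccccc32)ccc1CNC(=O)NCC(=O)O` is the unmeasured compound. It differs from compound 3 in this respect: carboxymethyl in place of 2,6-difluorophenyl on an amide-type nitrogen. Within the data shown here, no measured step touches this nitrogen; the one measured step, from compound 1 to compound 2, concerns a different ring and offers no guide to the size of what follows here. The expectation therefore rests on the scale of the change alone, which removes the whole aromatic ring from that urea nitrogen, and a large rise in the number, well beyond the scatter, is expected for the step of a 240-fold higher number from compound 3 to compound 4 (2.38 log units; beyond the scatter). For compound 4 an estimated value of 500 nM is expected in this assay, within a range from 40 nM to 10000 nM.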

Compound 4, half-maximal effective concentration: 180 nM
The estimate for compound 4 lay 2.8-fold (0.44 log units) above the measured number, within the range that was stated.
By their numbers in this assay, from the lowest: compound 3; then compound 2; then compounds 1 and 4 (each within the scatter of the next).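

Compounds 1, 2 and 3 all carry 2,6-difluorophenyl on the amide-type nitrogen, so compound 4 is the first of the compounds shown to test this position, and in this assay the exchange for carboxymethyl gives an 86-fold higher number from compound 3 to compound 4 (1.93 log units; beyond the scatter), a large step that shows the number depends strongly on the group held there. The response is not lost with the ring, however: with no aromatic ring left on this nitrogen, compound 4 still gives 180 nM in the same read-out. Nothing measured here accounts for the size of this step, and the result stands as an observation without an established cause.

The single exchange removes the 2,6-difluorophenyl and introduces the carboxymethyl together, so the compounds shown cannot separate the loss of the ring from the arrival of the new group; an unsubstituted phenyl, a plain methyl or a benzyl on the same nitrogen would bear on that question. Also open, from the compounds shown here alone, is how a longer chain such as carboxyethyl, or the methyl ester of the carboxymethyl group, would read at this position, and whether the step would keep its size with chloro or fluoro in place of the methyl on the other ring.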